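Chloro for iodo on the ethenyl chain: cytotoxicity notes

A few compounds are considered here, and "the series" means these few. Any claim that something is new, unique, unknown or untested is made for them only; others in the source may bear on it.

Measured in an ADME assay on L1210/0 cells (Mus musculus) for cytotoxicity, with a stated time of 48 h; a higher number here means a weaker inhibitor, a lower number a stronger inhibitor:
compound 1 `O=c1[nH]c(=O)n([C@H]2C[C@H](O)[C@@H](CO)O2)cc1/C=C/I`: 63900 nM
compound 2 `Nc1ncnc2c1ncn2C[C@@H]1C[C@H](CO)c2ccccc21`: limit, > 200000 nM
compound 3 `O=c1[nH]c(=O)n(C2C[C@@H](CO)[C@@H](CO)C2)cc1I`: limit, > 200000 nM

Among the measured compounds shown here, compound 1 carries the only number in this assay. Compound 2 reaches only the limit of the assay. Compound 3 likewise reaches only the limit. For the measured compounds named here, two of the three values shown are the limit of > 200000 nM in this assay, at which 2 of the 3 values shown sit, so no step between measured compounds can be read.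

Compound 4 `O=c1[nH]c(=O)n([C@H]2C[C@H](O)[C@@H](CO)O2)cc1/C=C/Cl` differs from compound 1 by chloro in place of iodo on a double-bonded chain carbon bound to a double-bonded chain carbon. Nothing measured here shows what this change does, so for this assay a step of no size beyond the scatter is expected, in neither direction. For compound 4 the estimate is 80000 nM, range 25000 nM to 250000 nM, because compound 1 gives 63900 nM. The step expected a 1.3-fold higher number from compound 1 to compound 4 (0.10 log units; within the scatter) stays within the usual scatter.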

Compound 4, half-maximal inhibitory concentration: > 200000 nM
Compound 4 gave a limit, no number (the forecaster's own chance of this, stated with the estimate: 30%); middle value at least 2.5-fold (0.39 log units) away from the limit.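

Among the compounds shown here, this is the first readable step at this position: in this assay, chloro in place of iodo on a double-bonded chain carbon bound to a double-bonded chain carbon gives an at least 3.1-fold higher number from compound 1 to compound 4 (0.49 log units; beyond the scatter). Compound 4 gives > 200000 nM, which is a limit and not a number. The 2-iodoethenyl group of compound 1 therefore goes with the only number shown, and the full size of the step stays unknown because compound 4 gives only a limit: the limit of > 200000 nM in this assay, at which 3 of the 4 values shown sit.

As far as these compounds go, whether a 2-bromoethenyl group or a longer chain on the core of compound 1 would give a number remains open. For the compounds shown here, no step involving compound 2 or compound 3 can be read.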